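This account rests on a few compounds, and the source may have more. Where it says the series, first, only, none or still open, it means among the compounds named here.

Compound 3 `COc1cc(Cl)cc(-c2nn(-c3cccc(NC(=O)Nc4cccc(C(F)(F)F)c4)c3)cc2-c2ccncc2)c1` gives 57% in a functional assay on CAKI-1 cells (Homo sapiens) for inhibition, read by sulforhodamine B assay, with a stated time of 48 h, tested at 1 uM (on this read-out higher numbers stand for a weaker effect at the one concentration tested and lower numbers for a stronger effect), which places it second highest of the three numbers recorded. Compound 1 `COc1cc(Cl)cc(-c2nn(-c3cccc(NC(=O)Nc4ccc(Cl)c(C(F)(F)F)c4)c3)cc2-c2ccncc2)c1` gives 45% in this assay, and compound 2 `COc1cc(Cl)cc(-c2nn(-c3cccc(NC(=O)Nc4ccc(Cl)c(Cl)c4)c3)cc2-c2ccncc2)c1` gives 79% in this assay. The measured steps were a number 12 percentage points higher from compound 1 to compound 3 (beyond the scatter), a number 34 percentage points higher from compound 1 to compound 2 (beyond the scatter) and a number 22 percentage points lower from compound 2 to compound 3 (beyond the scatter); each of them changes only the substituents of the outer aryl group, and none of them touches the atoms joining that aryl group to the carbonyl carbon. Compound 4 `COc1cc(Cl)cc(-c2nn(-c3cccc(NC(=O)c4cccc(C(F)(F)F)c4)c3)cc2-c2ccncc2)c1` differs from compound 3 in one place: 3-(trifluoromethyl)phenyl in place of (3-(trifluoromethyl)phenyl)amino on a carbonyl carbon. For the measured compounds named here, no measured step bears directly on this kind of change, so the three recorded steps show only that this set moves by modest to large amounts in this assay when the outer aryl portion is varied, and they give no firm direction for compound 4. The expected step is therefore a number 8 percentage points higher from compound 3 to compound 4 (within the scatter), a movement judged likely to stay within or only modestly beyond the scatter, with a slight lean toward a higher number. Compound 4 is accordingly estimated at 65% in this assay, within a range from 45% to 90%.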

Compound 4, a percentage reported as activity, at one concentration (the size of the read-out at that concentration, not a potency): 90%
Estimate against measurement, compound 4: 25 percentage points below, and the stated range covers the measured number.
By their numbers in this assay, from the lowest: compound 1; then compound 3; then compound 2; then compound 4.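

In this assay, the link to the outer aryl group proves at least as sensitive as that group's substituents: putting 3-(trifluoromethyl)phenyl directly on the carbonyl carbon in place of (3-(trifluoromethyl)phenyl)amino, which removes one nitrogen and one hydrogen-bond donor, gives a number 33 percentage points higher from compound 3 to compound 4 (beyond the scatter), in the same large class as the earlier a number 34 percentage points higher from compound 1 to compound 2 (beyond the scatter). The amino link therefore matters here, and the other two comparisons point the same way, with a number 11 percentage points higher from compound 2 to compound 4 (beyond the scatter) and a number 45 percentage points higher from compound 1 to compound 4 (beyond the scatter), so that the highest number and the weakest effect at this one concentration among the four belong to the compound without that nitrogen. No supporting measurement is available to explain why this change has so large an effect.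

The compounds shown cannot separate the loss of the nitrogen from the loss of its hydrogen, and a methylamino link, a methylene or an oxygen on the carbonyl carbon would address that point. From the compounds shown here alone, it also remains open whether the ordering seen among the outer aryl groups on the amino link would carry over to aryl groups placed directly on the carbonyl carbon, such as 3,4-dichlorophenyl.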